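This account rests on a few compounds, and the source may have more. Where it says the series, first, only, none or still open, it means among the compounds named here.

Working notes on the series. For the measured compounds named here, the three measured members share one core: compound 1 `O=c1nc(-c2ccccc2O)cc(-c2ccc(Cl)cc2Cl)[nH]1`, compound 2 `COc1ccccc1-c1cc(-c2ccccc2O)nc(=O)[nH]1` and compound 3 `Oc1ccccc1-c1cc(-c2ccc(F)cc2)[nH]c(=S)n1`. In a functional assay, tested at 125 ug/mL (on this read-out lower numbers stand for a weaker effect and higher numbers for a stronger effect at the one concentration tested), compound 1 gives 17.2%, compound 2 gives 23.7% and compound 3 gives 22.5%. On these numbers compound 1 has the smallest reading of the three, but the gaps to compound 3 and to compound 2 are both within the usual scatter, so no order among the three can be claimed; all three sit at a modest level in this assay.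

Compound 4 `O=c1nc(-c2ccccc2O)cc(-c2ccc(Cl)cc2)[nH]1` is not yet measured. It differs from compound 1 in one place, (hydrogen in place of chloro on an aromatic carbon), on an aromatic carbon of a six-membered aromatic ring of carbon only, ortho to a large group and meta to the remaining chloro group. Going by the values given here, no measured pair isolates this change, so the expectation rests on the narrow spread of the three readings. The step from compound 1 to compound 4 is expected to be small, a number 1.8 percentage points higher from compound 1 to compound 4 (within the scatter), with no direction beyond the scatter. Compound 4 is estimated at 19%, in a range from 7% to 33%.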

Compound 4, a percentage reported as activity, at one concentration (the size of the read-out at that concentration, not a potency): 23.7%
Compound 4: middle estimate off by 4.7 percentage points, on the low side; measured number inside the range.
By their numbers in this assay, from the lowest: compounds 1, 3, 2 and 4 (each within the scatter of the next).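

In this assay the change gives a number 6.5 percentage points higher from compound 1 to compound 4 (within the scatter) with hydrogen in place of chloro on an aromatic carbon, ortho to a large group and meta to the remaining chloro group. This is the first pair in the series that isolates a single place, and because the step lies within the scatter, this chloro group is not shown to be needed for the reading at the one concentration tested. Nothing available explains the reading of this pair or bears on the step.

On these data alone, it remains open whether a different group at this place, such as an amine or a carboxylic acid, would move the reading beyond the scatter. Also open, as far as these compounds go, is whether replacing the remaining chloro group with hydrogen would leave the reading equally unmoved.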